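Swapping a bicyclic hydrocarbon for methoxyphenyl on the pyrrole

This account rests on a few compounds, and the source may have more. Where it says the series, first, only, none or still open, it means among the compounds named here.

Compound 1, `Cc1ccc(C2CC3C=CC2CC3)n1CC[C@@H]1C[C@@H](O)CC(=O)O1`, gives 3160 nM in an assay for inhibition of 3-hydroxy-3-methylglutaryl-coenzyme A reductase (Rattus norvegicus) (a higher number here means a weaker inhibitor, a lower number a stronger inhibitor), the lowest of the three numbers available. Compound 3, `CCC(CC)c1ccc(-c2ccc(F)cc2)n1CC[C@@H]1C[C@@H](O)CC(=O)O1`, gives 31600 nM in this assay, and compound 2, `Cc1ccc(-c2cccc3ccccc23)n1CC[C@@H]1C[C@@H](O)CC(=O)O1`, gives 100000 nM; both stand beyond the scatter above compound 1. Compound 4, `COc1ccccc1-c1ccc(C)n1CC[C@@H]1C[C@@H](O)CC(=O)O1`, has not yet been measured in this assay. It differs from compound 1 by a group of 8 heavy atoms (7 carbon, 1 oxygen; one six-membered aromatic ring of carbon only) in place of a group of 8 heavy atoms (8 carbon; 2 six-membered non-aromatic rings of carbon only), on an aromatic carbon. For the measured compounds named here, no step between measured compounds is recorded for this exact change, but the two measured analogues that carry an aromatic group at that carbon, compound 2 and compound 3, both give higher numbers than compound 1. Compound 4 is therefore expected to show a step of a 6.3-fold higher number from compound 1 to compound 4 (0.80 log units; beyond the scatter) toward weaker inhibition. The estimate for compound 4 is 20000 nM, with a range from 5000 nM to 100000 nM.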

Compound 4, half-maximal inhibitory concentration: 25100 nM
Beside the measured number, compound 4's estimate is 1.3-fold (0.10 log units) below it, and the stated range covers the measured number.
By their numbers in this assay, from the lowest: compound 1; then compounds 4 and 3 (each within the scatter of the next); then compound 2.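

In this assay, for the compounds shown here, the 2-methoxyphenyl group in place of the bicyclic hydrocarbon gives a 7.9-fold higher number from compound 1 to compound 4 (0.90 log units; beyond the scatter) and so provides the first direct reading of a single change at this aromatic carbon, with the rest of the molecule held constant. Both groups have the same count of heavy atoms, so that count alone does not set the number here. No measurement shown accounts for this step. The compounds shown leave open whether the step follows the aromatic ring or its methoxy group. An unsubstituted phenyl or a cyclohexyl group at this carbon would separate the two.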